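Trading the Urea Arm of Compound 1 for a Benzamide

A few compounds are considered here, and "the series" means these few. Any claim that something is new, unique, unknown or untested is made for them only; others in the source may bear on it.

Compound 1: `COc1cc(-c2nn(-c3cccc(NC(=O)Nc4ccc(Cl)c(Cl)c4)c3)cc2-c2ccncc2)ccc1Cl` — in a functional assay on MDA-MB-468 cells (Homo sapiens) for inhibition, read by sulforhodamine B assay, with a stated time of 48 h (on this read-out lower numbers stand for higher toxicity in this test and higher numbers for lower toxicity in this test), compound 1 gives > 50000 nM, which is a limit of the test.
Compound 2: `O=C(Nc1cccc(-n2cc(-c3ccncc3)c(-c3ccc(Cl)c(O)c3)n2)c1)Nc1ccc(Cl)c(Cl)c1` — in this assay compound 2 gives > 32500 nM, also a limit.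
Compound 3: `O=C(Nc1cccc(-n2cc(-c3ccncc3)c(-c3ccc(Cl)c(O)c3)n2)c1)Nc1cc(C(F)(F)F)cc(C(F)(F)F)c1` — in this assay compound 3 gives 37100 nM.

Compound 1 stands at a limit of > 50000 nM in this assay, at which 1 of the 3 values shown sits, and is therefore not placed on a number at all; compound 2 sits at the other limit (the limit of > 32500 nM in this assay, at which 1 of the 3 values shown sits), so the step that the two limits leave unreadable from compound 1 to compound 2 cannot be sized. Only compound 3 gives a readable number, and it is weak.

The step to compound 4 `COc1cc(-c2nn(-c3cccc(NC(=O)c4ccccc4)c3)cc2-c2ccncc2)ccc1Cl` is phenyl in place of (3,4-dichlorophenyl)amino on a carbonyl carbon. Among the measured compounds shown here, no measured step touches this position, since the change from compound 1 to compound 2 lies on the oxygen elsewhere in the molecule and compound 3 differs from compound 1 in two places. With every measured compound weak or at a limit, compound 4 is expected to stay in the same region, and the step of a number no higher from compound 1 to compound 4 (the limit leaves the size open) is expected to be none beyond the scatter. Compound 4 is estimated at 50000 nM, within 20000 nM to 120000 nM, most likely reported as a limit.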

Compound 4, concentration lethal to 50% of the cells: > 100000 nM
Compound 4 ended at the assay's limit; the forecaster's own chance of this, stated with the estimate: 70%; at least 2.0-fold (0.30 log units) between middle value and limit.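

The step from compound 1 to compound 4 cannot be read, as each compound stands at a limit in this assay rather than at a number. The compounds shown leave open whether phenyl in place of (3,4-dichlorophenyl)amino on a carbonyl carbon changes toxicity in this test at all.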